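Adding a Methyl to the Core of Compound 3

The source may hold more compounds than are shown below. What is called first, only, known or untested is meant among the compounds shown, and "the series" means these compounds.

Measured compounds:
Compound 1 `Cc1cc(C)c2c(O)cc(-c3ccc(Cl)cc3)nc2n1` gives 30200 nM in a functional assay on U-251 cells (Homo sapiens); a lower number here means a stronger inhibitor of growth, a higher number a weaker inhibitor of growth.
Compound 2 `Cc1ccnc2nc(-c3ccc(Cl)cc3)cc(O)c12` gives 4570 nM in this assay.
Compound 3 `COc1ccccc1-c1cc(O)c2cccnc2n1` gives 67600 nM in this assay.

Compound 2 and compound 1 differ in one place: methyl in place of hydrogen on an aromatic carbon. That step, a 6.6-fold higher number from compound 2 to compound 1 (0.82 log units; beyond the scatter), raised the number. Compound 3 has another core; how its core differs from that of compound 2 is not broken down here. Among the three, compound 3 gives the highest number, beyond the scatter from both others.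

Compound 4 `COc1ccccc1-c1cc(O)c2cc(C)cnc2n1` is not yet measured. It differs from compound 3 by methyl in place of hydrogen on an aromatic carbon. This is the same kind of change as from compound 2 to compound 1, but the place is not the same: in compound 1 the methyl is next to the ring nitrogen and meta to a methyl group, in compound 4 it is two atoms from the ring nitrogen. Among the compounds with values here, only one measured step of this kind exists, and it sits at a different place. The step expected for compound 4 in this assay is a 1.8-fold higher number from compound 3 to compound 4 (0.25 log units; within the scatter), an increase resting on compound 1 with a 6.6-fold higher number from compound 2 to compound 1 (0.82 log units; beyond the scatter). The estimate for compound 4 is 120000 nM, expected between 40000 nM and 400000 nM.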

Compound 4, concentration for 50% growth inhibition: 27500 nM
The estimate for compound 4 lay 4.4-fold (0.64 log units) above the measured number; the whole stated range lies above it.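

On the core of compound 3, the methyl gave a 2.5-fold lower number from compound 3 to compound 4 (0.39 log units; beyond the scatter) in this assay, so the change that raised the number on the core of compound 2 lowered it here. The change therefore did not carry over from one core to the other with the same direction or size: the same change on two cores in this assay, a 6.6-fold higher number (0.82 log units; beyond the scatter) from compound 2 to compound 1 and a 2.5-fold lower number (0.39 log units; beyond the scatter) from compound 3 to compound 4, 16-fold (1.21 log units) apart, beyond the scatter of two such steps. This does not show what sets the two steps apart, since the pairs differ in more than the core: the methyl sits at a different place, and compound 1 and compound 2 carry a chlorophenyl group where compound 3 and compound 4 carry a methoxyphenyl group.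

The compounds shown leave open whether a methyl two atoms from the ring nitrogen would also lower the number on a core bearing the chlorophenyl group. They also leave open whether an ethyl chain or an amine at that place on the core of compound 3 would move the number the same way as methyl.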